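A few compounds are considered here, and "the series" means these few. Any claim that something is new, unique, unknown or untested is made for them only; others in the source may bear on it.

Among the compounds with values here, compound 1, `Cc1ccc([C@@H]2CN(C)[C@]3(C(=O)Nc4ccccc43)[C@]23Cc2ccccc2C3=O)cc1`, has the lowest number of the three compounds measured so far in a functional assay on the whole organism (strain Wister albino) for inhibition, with Rattus norvegicus as the target, read by paw edema, with stated times of 1 h and 2 h, at a dose of 50 mg/kg by the intraperitoneal route (a higher number here means more inhibition at the dose given (going by the name of the read-out), a lower number less inhibition), where compound 1 gives 23.8%. Compound 2, `CN1C[C@@H](c2ccccc2)[C@@]2(Cc3ccccc3C2=O)[C@@]12C(=O)Nc1ccccc12`, gives 40% in this assay, and compound 3, `CN1C[C@@H](c2cccs2)[C@@]2(Cc3ccccc3C2=O)[C@@]12C(=O)Nc1ccccc12`, gives 39.1%. Both sit well above compound 1: the change from methyl to hydrogen on the aromatic carbon gave a number 16.2 percentage points higher from compound 1 to compound 2 (beyond the scatter), and replacing the 4-methylphenyl with thiophen-2-yl gave a number 15.3 percentage points higher from compound 1 to compound 3 (beyond the scatter). Between compound 2 and compound 3 the step was a number 0.9 percentage points lower from compound 2 to compound 3 (within the scatter), so the phenyl and the thiophen-2-yl cannot be told apart in this assay.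

Compound 4, `CN1C[C@@H](c2ccc(Cl)cc2)[C@@]2(Cc3ccccc3C2=O)[C@@]12C(=O)Nc1ccccc12`, differs from compound 1 by chloro in place of methyl on an aromatic carbon, which reads one bond further out as 4-methylphenyl to 4-chlorophenyl. Within the data shown here, the step that bears most directly on it is the removal of the methyl from compound 1 to compound 2, which was beyond the scatter; no chloro analogue has been measured, so the data cannot tell whether chloro behaves like hydrogen or like methyl at this position. On balance an increase is expected, with the step from compound 1 to compound 4 estimated at a number 10.2 percentage points higher from compound 1 to compound 4 (beyond the scatter). Compound 4 is therefore estimated to give 34% in this assay, with a range from 22% to 46%.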

Compound 4, a percentage reported as inhibition, in the whole organism at one dose (the size of the read-out at that dose, not a potency): 28.4%
Compound 4: middle estimate off by 5.6 percentage points, on the high side; the measured number falls inside the stated range.
By their numbers in this assay, from the lowest: compounds 1 and 4 (each within the scatter of the next); then compounds 3 and 2 (each within the scatter of the next).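

In this assay, chloro in place of methyl on the aromatic carbon para to a large group gave a number 4.6 percentage points higher from compound 1 to compound 4 (within the scatter), so these two groups cannot be told apart at this position. Chloro in place of hydrogen at the same carbon gave a number 11.6 percentage points lower from compound 2 to compound 4 (beyond the scatter), which shows that the earlier gain on removing the methyl was not specific to methyl: among these compounds, both groups at this carbon read lower than hydrogen, and no compound shown goes against this. The 4-chlorophenyl compound also separates from the thiophen-2-yl compound, with a number 10.7 percentage points lower from compound 3 to compound 4 (beyond the scatter), placing compounds 1 and 4 together as a lower pair below compounds 2 and 3, though nothing available explains this difference.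

Since only methyl and chloro are shown on this carbon, it remains open whether a methoxy group, an amine or a carboxylic acid there would read with compounds 1 and 4 or with compounds 2 and 3. Going by these compounds, it is also open whether a chloro on the thiophen-2-yl ring would lower the number as it does on the phenyl ring.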